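The source may hold more compounds than are shown below. What is called first, only, known or untested is meant among the compounds shown, and "the series" means these compounds.

- compound 1 `COc1cc(N2C(=O)[C@@H](Oc3ccccc3)[C@H]2c2cccc3ccccc23)cc(OC)c1OC` gives 53000 nM
- compound 2 `COc1cc(N2C(=O)[C@@H](Oc3ccccc3)[C@H]2c2ccc(N=[N+]=[N-])cc2)cc(OC)c1OC` gives 23000 nM
- compound 3 `COc1cc([N+](=O)[O-])c([C@@H]2[C@H](Oc3ccccc3)C(=O)N2c2cc(OC)c(OC)c(OC)c2)cc1O` gives 59000 nM

These values come from a functional assay on MCF7 cells (Homo sapiens) for antiproliferative activity, read by MTT assay, with stated times of 24 h and 72 h; a higher number here means a weaker inhibitor, a lower number a stronger inhibitor. Compound 3 sits at the weak end of this small set, level with compound 1 (a 1.1-fold higher number from compound 1 to compound 3 (0.05 log units; within the scatter)). Compound 4 `COc1cc(N2C(=O)[C@@H](Oc3ccccc3)[C@H]2c2ccc(N)cc2)cc(OC)c1OC` brings one change: a group of 7 heavy atoms (6 carbon, 1 nitrogen; one six-membered aromatic ring of carbon only) in place of a group of 12 heavy atoms (7 carbon, 1 nitrogen, 4 oxygen; one six-membered aromatic ring of carbon only), on a saturated ring carbon. For the measured compounds named here, the closest precedent is compound 2, which carries 4-azidophenyl at that place (a 2.6-fold higher number from compound 2 to compound 3 (0.41 log units; beyond the scatter)). The other step that bears on this is a 2.3-fold lower number from compound 1 to compound 2 (0.36 log units; beyond the scatter). Going by the values given here, no measured compound carries 4-aminophenyl itself, so only a modest step towards a lower number is expected. The expected step is a 2.0-fold lower number from compound 3 to compound 4 (0.29 log units; within the scatter). Compound 4 is estimated at about 30000 nM, within a range of 11000 nM to 75000 nM.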

Compound 4, half-maximal inhibitory concentration: 160000 nM
Beside the measured number, compound 4's estimate is 5.3-fold (0.73 log units) below it; measured number outside the range, above it.
By their numbers in this assay, from the lowest: compound 2; then compounds 1 and 3 (each within the scatter of the next); then compound 4.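

The cleanest reading here is amino in place of azido on the same aromatic carbon, which gives the largest step in this set (a 7.0-fold higher number from compound 2 to compound 4 (0.84 log units; beyond the scatter)), so a small change on this ring can shift the number well beyond the scatter. 4-Aminophenyl also falls behind the other two groups on the saturated ring carbon (a 3.0-fold higher number from compound 1 to compound 4 (0.48 log units; beyond the scatter); a 2.7-fold higher number from compound 3 to compound 4 (0.43 log units; beyond the scatter)). Nothing shown here explains this loss. From the compounds shown here alone, whether an acetamide or a carboxylic acid in place of the amino group would give a number nearer compound 2 or nearer compound 4 stays open.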